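A (dimethylamino)methyl added to the core of compound 1

The source may hold more compounds than are shown below. What is called first, only, known or untested is meant among the compounds shown, and "the series" means these compounds.

Measured so far:
compound 1, `Cc1nc(-c2ccc(F)cc2)ccc1C(=O)Nc1ccc2scnc2c1`: in an in vitro functional assay on 1321-N1 cells for antagonist activity at transient receptor potential cation channel subfamily V member 1 (Homo sapiens), read by FLIPR and calcium flux (a lower number here means a less potent compound, a higher number a more potent compound, by a factor of ten per unit of this negative logarithm), compound 1 gives 7.5
compound 2, `Cc1nc(-c2ccc(F)cc2)ccc1C(=O)Nc1ccc2nc[nH]c2c1`: in the same assay compound 2 gives 7.2

Compound 1 holds the higher of the two numbers, but compound 2 lies within the usual scatter of it, so the two cannot be told apart. Compound 3, `Cc1nc(-c2ccc(F)cc2)ccc1C(=O)Nc1ccc2sc(CN(C)C)nc2c1`, is not yet measured; it differs from compound 1 by (dimethylamino)methyl in place of hydrogen on an aromatic carbon. Going by the values given here, no pair of measured compounds differing in one place exists to show what a change of this kind does, so the expectation rests on compound 1 alone. Expected is a number 0.20 log units lower from compound 1 to compound 3 (within the scatter), a step not larger than the scatter, in either direction. Compound 3 is estimated at 7.3, with a range from 6.5 to 8.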

Compound 3, negative logarithm of the antagonist equilibrium constant: < 6.7
Compound 3: a limit, no number (the forecaster's own chance of this, stated with the estimate: 5%); middle value at least 0.60 log units from the limit.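

Compound 3 carries a limit of the assay, not a number: the limit of < 6.7 in this assay, at which 1 of the 3 values shown sits.

With (dimethylamino)methyl in place of hydrogen on the aromatic carbon next to the ring nitrogen and next to the ring sulfur, the series shows a number at least 0.80 log units lower from compound 1 to compound 3 (beyond the scatter). Going by these compounds alone, this is the first sign that this position does not accept every group, something compound 1 and compound 2 could not show.

Going by these compounds, the full size of the step stays open. Also open, on these data alone, is whether a methyl, a hydroxymethyl or a primary aminomethyl on this carbon would behave the same way.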